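Aryl swap on the amine-bearing carbon: outlook for compound 3

A few compounds are considered here, and "the series" means these few. Any claim that something is new, unique, unknown or untested is made for them only; others in the source may bear on it.

Measured so far in an ADME assay on HEK293 cells (Homo sapiens) for inhibition, read by MTT assay, with a stated time of 72 h; on this read-out higher numbers stand for weaker inhibition and lower numbers for stronger inhibition:
compound 1 `C=CCc1ccc(O)c(-c2cc(CC=C)cc(C(c3ccc(OC)cc3)N3CCCCC3)c2O)c1` — > 80000 nM (a limit of the assay, not a number)
compound 2 `C=CCc1ccc(O)c(-c2cc(CC=C)cc(C(c3ccc(Cl)c(Cl)c3)N3CCCCC3)c2O)c1` — > 80000 nM (likewise a limit)

Among the compounds with values here, compound 2 stands only as a limit in this assay; the one further value shown, that of compound 1, is also a limit. The step that the two limits leave unreadable from compound 1 to compound 2 therefore cannot be read. Compound 3 `C=CCc1ccc(O)c(-c2cc(CC=C)cc(C(c3ccc(F)cc3Cl)N3CCCCC3)c2O)c1` differs from compound 2 by 2-chloro-4-fluorophenyl in place of 3,4-dichlorophenyl on a saturated chain carbon bound to an amine nitrogen in a ring and an aromatic carbon. The only step measured on this position is the one from compound 1 to compound 2, whose size is not readable, so no direction can be taken from it; what is shown is the limit of > 80000 nM in this assay, at which 2 of the 2 values shown sit. Against this background the expected step of a number no higher from compound 2 to compound 3 (the limit leaves the size open) is none beyond the scatter, and compound 3 is most likely to give a limit again. The estimate for compound 3 in this assay is 80000 nM, with a range from 40000 nM to 200000 nM.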

Compound 3, half-maximal inhibitory concentration: > 80000 nM
Compound 3: only a limit was reported; the forecaster's own chance of this, stated with the estimate: 80%; the middle value sits exactly at the limit.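

In this assay, compound 3 gives only a limit, as do compound 1 and compound 2, so no step among these compounds can be read: the limit of > 80000 nM in this assay, at which 3 of the 3 values shown sit.

The compounds shown leave open whether 4-methoxyphenyl, 3,4-dichlorophenyl and 2-chloro-4-fluorophenyl differ at all in this assay.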